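Removing the Allyl Group from a Weak Cytotoxic Scaffold

The source may hold more compounds than are shown below. What is called first, only, known or untested is meant among the compounds shown, and "the series" means these compounds.

Measured compounds:
compound 1 `COc1ccccc1/C=c1/[nH]c(=O)/c(=C\c2cccc(Cl)c2Cl)[nH]c1=O`: "not active" (no number reported)
compound 2 `C=CCn1c(=O)/c(=C\c2ccccc2OC)[nH]c(=O)/c1=C\c1ccccc1OC`: 21500 nM

Going by the values given here, in a functional assay on NCI-H1975 cells (Homo sapiens) for cytotoxicity, read by CCK-8 assay, with a stated time of 72 h (on this read-out higher numbers stand for weaker inhibition and lower numbers for stronger inhibition), compound 2 gives 21500 nM, which is the only number available in this set, and it stands for weak inhibition. Compound 1 in this assay is reported as "not active" (no number reported), without any number, so it cannot be set beside compound 2 on a scale.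

Compound 3 `COc1ccccc1/C=c1/[nH]c(=O)/c(=C\c2ccccc2OC)[nH]c1=O` differs from compound 2 in one place: hydrogen in place of allyl on an aromatic nitrogen. Among the compounds with values here, no measured pair in this set shows the effect of exactly this change, so the size of the step is uncertain. Compound 1 also carries a hydrogen on that ring nitrogen, and it is expected that compound 3 will sit on the weaker side because compound 1 was reported as "not active" (no number reported). The expected step of a 2.1-fold higher number from compound 2 to compound 3 (0.32 log units; beyond the scatter) is toward weaker inhibition, beyond the usual scatter. Compound 3 is therefore estimated at 45000 nM, with a range from 15000 nM to 200000 nM.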

Compound 3, half-maximal inhibitory concentration: "not active" (no number reported)
The entry for compound 3 holds no number; the estimate stays without a comparison.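

In this assay, going by these compounds alone, compound 3 gives "not active" (no number reported), so no step from compound 2 can be read. No supporting data bear on this result. The compounds shown leave open how large the change is when hydrogen replaces allyl on the aromatic nitrogen.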